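The source may hold more compounds than are shown below. What is called first, only, known or untested is meant among the compounds shown, and "the series" means these compounds.

Measured in a functional assay on PC-3 cells (Homo sapiens) for cytotoxicity, read by MTT assay, with a stated time of 72 h; a higher number here means a weaker inhibitor, a lower number a stronger inhibitor:
- Compound 1 `CC(=O)c1ccc(/N=C2\C=C(OCc3cn(S(=O)(=O)c4ccc(C)cc4)nn3)C(=O)c3ccccc32)cc1`: 3910 nM
- Compound 2 `COc1ccc(/N=C2\C=C(OCc3cn(S(=O)(=O)c4ccc(C)cc4)nn3)C(=O)c3ccccc32)cc1`: > 20000 nM

Compound 2 gives > 20000 nM, which is a limit of the assay and not a number. Compound 3 `Cc1ccc(S(=O)(=O)n2cc(COC3=C/C(=N\c4ccc(Cl)cc4)c4ccccc4C3=O)nn2)cc1` has not yet been measured. It differs from compound 2 by chloro in place of methoxy on an aromatic carbon, turning 4-methoxyphenyl into 4-chlorophenyl (chloro in place of methoxy on an aromatic carbon).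

For the measured compounds named here, one measured step bears on this change, methoxy in place of acetyl on an aromatic carbon: an at least 5.1-fold higher number from compound 1 to compound 2 (0.70 log units; beyond the scatter). Going by the values given here, no measured compound yet carries chloro, so that step is only a rough guide. Leaving methoxy is expected to move the number down, by somewhat less than the size of the step to compound 2 an at least 5.1-fold higher number from compound 1 to compound 2 (0.70 log units; beyond the scatter). The expected step is an at least 2.5-fold lower number from compound 2 to compound 3 (0.39 log units; beyond the scatter). Compound 3 is expected to give 8000 nM. Its estimated range runs from 2500 nM to 20000 nM.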

Compound 3, half-maximal inhibitory concentration: > 20000 nM
Compound 3 gave a limit, no number; the forecaster's own chance of this, stated with the estimate: 25%; middle value at least 2.5-fold (0.39 log units) away from the limit.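

In this assay compound 3 gives > 20000 nM, which is a limit of the assay and not a number. Chloro in place of acetyl on this aromatic carbon, para to a large group, gives an at least 5.1-fold higher number from compound 1 to compound 3 (0.70 log units; beyond the scatter), so the loss seen with methoxy is no longer confined to that one group, and acetyl alone among the three gives a readable number. The step from compound 2 to compound 3 cannot be read, and the two compounds cannot be placed in any order: the limit of > 20000 nM in this assay, at which 2 of the 3 values shown sit.

On these data alone, whether another group on this carbon, such as an amine, a carboxylic acid or a methyl ester, would give a readable number as acetyl does remains open. Also open, as far as these compounds go, is whether compound 2 and compound 3 differ at all in this assay.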